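Adding One Carbon to the Chain: Expected Effect

The compounds below may be only part of what the source reports. "The series", "measured", "known", "first", "only" and "open" are said of these compounds alone.

Measured so far:
compound 1, `CCCCCCCCCC(=O)CC(=O)Nc1c(C(C)C)cccc1C(C)C`: 97 nM
compound 2, `CCCCCCCCCCC(=O)CC(=O)Nc1c(C(C)C)cccc1C(C)C`: 60 nM

In a functional assay on microsomes from intestine for inhibition of acyl-CoA:cholesterol acyltransferase (Oryctolagus cuniculus) (a higher number here means a weaker inhibitor, a lower number a stronger inhibitor), compound 2 gives the lowest of the two numbers shown, but the step of a 1.6-fold lower number from compound 1 to compound 2 (0.21 log units; within the scatter) lies within the scatter, so the two compounds cannot be told apart. Compound 3, `CCCCCCCCCCCC(=O)CC(=O)Nc1c(C(C)C)cccc1C(C)C`, differs from compound 2 by methyl in place of hydrogen on a saturated chain carbon, ten or more bonds along the chain from a carbonyl carbon. Among the measured compounds shown here, the only step that bears on this is a 1.6-fold lower number from compound 1 to compound 2 (0.21 log units; within the scatter), the same kind of addition one bond nearer the carbonyl, and it stayed within the scatter. For compound 3 a shift of about a 1.2-fold lower number from compound 2 to compound 3 (0.08 log units; within the scatter) in this assay is therefore expected, nothing beyond the scatter. Compound 3 is estimated at 50 nM, in the range 25 nM to 110 nM.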

Compound 3, half-maximal inhibitory concentration: 69 nM
Compound 3: middle estimate off by 1.4-fold (0.14 log units), on the low side; the range from low to high includes it.
By their numbers in this assay, from the lowest: compounds 2, 3 and 1 (each within the scatter of the next).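

In this assay the methyl on a saturated chain carbon gives a 1.2-fold higher number from compound 2 to compound 3 (0.06 log units; within the scatter) and stays within the scatter, so this further addition cannot be told from no change. The larger change, ethyl in place of hydrogen, gives a 1.4-fold lower number from compound 1 to compound 3 (0.15 log units; within the scatter) and also stays within the scatter. No evidence here speaks to why these numbers lie so close. Still open, from the compounds shown here alone, is whether a much longer chain, or an amine or carboxylic acid on this chain, would move the number beyond the scatter.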